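Chain extension at the ester of a quinazoline-derived conjugate

The source may report more compounds than this note shows. Statements on the series, on what has been measured and on what is new or still open speak of the compounds shown alone.

Measured compounds:
compound 1 `CCCCCCCCCOC(=O)CCC(=O)N1CCN(CCCOc2cc3c(Nc4ccc(F)c(Cl)c4)ncnc3cc2OC)CC1`: 90%
compound 2 `CCCCCCCCCCCCCCCCOC(=O)CCC(=O)N1CCN(CCCOc2cc3c(Nc4ccc(F)c(Cl)c4)ncnc3cc2OC)CC1`: 97.7%

Of the compounds shown here, two sharing one core have been tested in a functional assay on A549 cells (Homo sapiens) for cytotoxicity, read by MTT assay, with a stated time of 24 h, tested at 10 uM; a lower number here means a stronger effect, a higher number a weaker effect of the compound at the concentration tested. Compound 1 gives 90%; compound 2 gives 97.7%. Going by the values given here, the one measured step, heptyl in place of hydrogen on a saturated chain carbon, nine bonds along the chain from an oxygen next to a carbonyl group, moved the read-out by a number 7.7 percentage points higher from compound 1 to compound 2 (within the scatter). Compound 2 therefore stands at the higher of the two numbers, but its separation from compound 1 lies within the scatter, so no order between them can be claimed.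

Compound 3 `CCCCCCCCCCCCCCCCCCOC(=O)CCC(=O)N1CCN(CCCOc2cc3c(Nc4ccc(F)c(Cl)c4)ncnc3cc2OC)CC1` has not yet been measured. It differs from compound 2 as follows: ethyl in place of hydrogen on a saturated chain carbon, ten or more bonds along the chain from an oxygen next to a carbonyl group. The step from compound 1 to compound 2 is the only one that bears on this change, and it lengthened the same chain without a shift beyond the scatter. A further lengthening of that chain is therefore expected to leave the read-out in this assay essentially where compound 2 sits, with a step of a number 0.7 percentage points lower from compound 2 to compound 3 (within the scatter) anticipated. Compound 3 is estimated at 97%, in the range 85% to 108%.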

Compound 3, a percentage reported as activity, at one concentration (the size of the read-out at that concentration, not a potency): 94.8%
The estimate for compound 3 lay 2.2 percentage points above the measured number; the range from low to high includes it.
By their numbers in this assay, from the lowest: compounds 1, 3 and 2 (each within the scatter of the next).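

In this assay, ethyl in place of hydrogen on a saturated chain carbon, ten or more bonds along the chain from an oxygen next to a carbonyl group, gives a number 2.9 percentage points lower from compound 2 to compound 3 (within the scatter) and so adds a second chain extension that stays within the scatter. Over the wider span, the whole extension of the chain gives a number 4.8 percentage points higher from compound 1 to compound 3 (within the scatter), so the three chains cannot be told apart and the series shows no dependence of the read-out on chain length, which a single step could not show. No measurement is at hand that would account for this flat result.

The compounds shown leave open whether a much shorter chain, such as methyl or propyl, would read the same in this assay as these three. They also leave open whether an amine or a carboxylic acid at the end of the chain would move the read-out beyond the scatter.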